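Replacing the Amine Substituent: What to Expect for Compound 4

The source may report more compounds than this note shows. Statements on the series, on what has been measured and on what is new or still open speak of the compounds shown alone.

Compound 1, `Cc1cn([C@@H]2O[C@H](CO[Si](C)(C)C(C)(C)C)[C@@]3(OS(=O)(=O)C=C3NC(=O)c3ccccc3)[C@H]2O[Si](C)(C)C(C)(C)C)c(=O)n(C)c1=O`, gives 4900 nM in a functional assay on MT4 cells (Homo sapiens); on this read-out higher numbers stand for lower toxicity in this test and lower numbers for higher toxicity in this test.
Compound 2, `COC(=O)C(=O)CNC1=CS(=O)(=O)O[C@@]12[C@@H](CO[Si](C)(C)C(C)(C)C)O[C@@H](n1cc(C)c(=O)n(C)c1=O)[C@@H]2O[Si](C)(C)C(C)(C)C`, gives 10300 nM in this assay.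
Compound 3, `Cc1cn([C@@H]2O[C@H](CO[Si](C)(C)C(C)(C)C)[C@@]3(OS(=O)(=O)C=C3NCC(=O)C(N)=O)[C@H]2O[Si](C)(C)C(C)(C)C)c(=O)n(C)c1=O`, gives 9590 nM in this assay.

Compound 3 stands second highest of the three numbers; its neighbour compound 2 sits within the scatter of it, and compound 1 also lies within the scatter, though at the far end. Compound 4, `Cc1cn([C@@H]2O[C@H](CO[Si](C)(C)C(C)(C)C)[C@@]3(OS(=O)(=O)C=C3NC(=O)NC(=O)c3ccccc3)[C@H]2O[Si](C)(C)C(C)(C)C)c(=O)n(C)c1=O`, differs from compound 3 in one place: benzoylcarbamoyl in place of (carbamoylcarbonyl)methyl on an amine nitrogen. The measured step that bears on this most closely runs the other way, from the benzoyl of compound 1 to the (carbamoylcarbonyl)methyl of compound 3, a 2.0-fold higher number from compound 1 to compound 3 (0.29 log units; within the scatter). The step of a 2.1-fold higher number from compound 1 to compound 2 (0.32 log units; beyond the scatter) points the same way and is modest. Since compound 4 brings the benzoyl group back while keeping one hydrogen-bond donor and two acceptors, the number in this assay is expected to move back toward that of compound 1, a step of a 1.6-fold lower number from compound 3 to compound 4 (0.20 log units; within the scatter), at the edge of the scatter. Compound 4 is therefore estimated at 6000 nM, with a range from 2500 nM to 14000 nM.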

Compound 4, half-maximal cytotoxic concentration: 3330 nM
The estimate for compound 4 lay 1.8-fold (0.26 log units) above the measured number, within the range that was stated.
By their numbers in this assay, from the lowest: compounds 4, 1, 3 and 2 (each within the scatter of the next, the first and the last beyond it).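

At this amine nitrogen, benzoylcarbamoyl gives a 2.9-fold lower number from compound 3 to compound 4 (0.46 log units; beyond the scatter) and a 3.1-fold lower number from compound 2 to compound 4 (0.49 log units; beyond the scatter) in this assay as steps wider than any among the three earlier compounds. Set against the benzoyl of compound 1, the same group gives a 1.5-fold lower number from compound 1 to compound 4 (0.17 log units; within the scatter) and so stays within the scatter, which leaves compound 4 as the only compound beyond the scatter of both compound 2 and compound 3. Nothing available here explains these steps.

On these data alone, what an acetyl group or a cyclohexyl ring in place of the phenyl of compound 4 would give remains open, as does the effect of a chlorine on that phenyl. As far as these compounds go, it is also open whether these steps would hold on a core carrying free hydroxyl groups in place of the silyl ethers.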